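Trading a hydroxy for three methoxy groups

A few compounds are considered here, and "the series" means these few. Any claim that something is new, unique, unknown or untested is made for them only; others in the source may bear on it.

Measured so far:
compound 1 `COc1ccc(CN(C(=O)CSc2nc3ccccc3s2)c2cc(OC)c(OC)c(OC)c2)cc1C` gives 6360 nM in a functional assay on MGC-803 cells (Homo sapiens) for antiproliferative activity, read by MTT assay, with a stated time of 48 h; a lower number here means a stronger inhibitor, a higher number a weaker inhibitor;
compound 2 `COc1cc(N(Cc2ccc(F)cc2)C(=O)CSc2nc3ccccc3s2)cc(OC)c1OC` gives > 80000 nM in this assay, a limit of the assay rather than a number;
compound 3 `COc1ccc(CN(C(=O)CSc2nc3ccccc3s2)c2cc(OC)c(OC)c(OC)c2)cc1O` gives 35 nM in this assay.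

Compound 3 stands as the lowest of the two numbers, a stronger inhibitor than compound 1 by a 180-fold lower number from compound 1 to compound 3 (2.26 log units; beyond the scatter). Its step from compound 2 is an at least 2200-fold lower number from compound 2 to compound 3 (3.35 log units; beyond the scatter), where compound 2 sits at the limit (the limit of > 80000 nM in this assay, at which 1 of the 3 values shown sits).

Compound 4 `COc1cc(CN(C(=O)CSc2nc3ccccc3s2)c2cc(OC)c(OC)c(OC)c2)cc(OC)c1OC` differs from compound 3 by 3,4,5-trimethoxyphenyl in place of 3-hydroxy-4-methoxyphenyl on a saturated chain carbon bound to an amide-type nitrogen. The measured steps that bear on this change are the ones that alter the same ring: a 180-fold lower number from compound 1 to compound 3 (2.26 log units; beyond the scatter) shows that a hydroxy in place of methyl brought a large gain, and an at least 12-fold higher number from compound 1 to compound 2 (1.09 log units; beyond the scatter) shows a large loss on a different change of that ring. Compound 4 gives up the hydroxy group, so a large rise in number, toward a weaker inhibitor, is expected; the step is estimated as an 86-fold higher number from compound 3 to compound 4 (1.93 log units; beyond the scatter). For compound 4 the expected value is 3000 nM, estimated between 400 nM and 25000 nM.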

Compound 4, half-maximal inhibitory concentration: 45700 nM
For compound 4 the middle estimate is 15-fold (1.18 log units) below the measured one; the measured number lies above the stated range.
By their numbers in this assay, from the lowest: compound 3; then compound 1; then compound 4. At a limit, above all of these: compound 2.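

In this assay the change to 3,4,5-trimethoxyphenyl gives a 1300-fold higher number from compound 3 to compound 4 (3.12 log units; beyond the scatter) and so shows how much depends on this ring: compound 3 is the only one of the four whose ring here carries a hydrogen-bond donor, and it has the lowest number. More methoxy groups do not make up for that donor, as a 7.2-fold higher number from compound 1 to compound 4 (0.86 log units; beyond the scatter) follows from replacing 4-methoxy-3-methylphenyl with 3,4,5-trimethoxyphenyl. As far as these compounds go, compound 2 stands at a limit rather than a number: the limit of > 80000 nM in this assay, at which 1 of the 4 values shown sits. Replacing 4-fluorophenyl with 3,4,5-trimethoxyphenyl therefore yields only a floor, namely an at least 1.7-fold lower number from compound 2 to compound 4 (0.24 log units; that floor lies within the scatter) and no more, so the order of these two compounds stays open.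

From the compounds shown here alone, the step from compound 3 to compound 4 removes the hydroxy and adds a methoxy group at once, so the share of each remains open. Also open, going by these compounds, is whether an amine or a carboxylic acid in place of the hydroxy would keep the number as low as in compound 3.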